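From compound 3 to compound 4: a larger ring

The source may report more compounds than this note shows. Statements on the series, on what has been measured and on what is new or still open speak of the compounds shown alone.

Of the compounds shown here, three sharing one core have been measured in a toxicity assay on L02 cells (Homo sapiens) for cytotoxicity, read by MTT assay, with a stated time of 72 h; a higher number here means a weaker inhibitor, a lower number a stronger inhibitor. There compound 1 `O=C1c2c[n+]([O-])c3ccccc3c2C(=O)c2c1c1ccccc1n2Cc1cn(CC(O)CO)nn1` gives 1070 nM, compound 2 `CC1(C)OC[C@H](Cn2cc(Cn3c4c(c5ccccc53)C(=O)c3c[n+]([O-])c5ccccc5c3C4=O)nn2)O1` gives 470 nM and compound 3 `O=C1c2c[n+]([O-])c3ccccc3c2C(=O)c2c1c1ccccc1n2Cc1cn([C@H]2C[C@H](O)[C@@H](CO)O2)nn1` gives 280 nM. The widest gap among them is a 3.8-fold lower number from compound 1 to compound 3 (0.58 log units; beyond the scatter). The closest pair shows a 1.7-fold lower number from compound 2 to compound 3 (0.22 log units; within the scatter), so those two cannot be told apart, and the remaining gap is a 2.3-fold lower number from compound 1 to compound 2 (0.36 log units; beyond the scatter).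

Compound 4 `O=C1c2c[n+]([O-])c3ccccc3c2C(=O)c2c1c1ccccc1n2Cc1cn([C@@H]2O[C@H](CO)[C@@H](O)[C@H](O)[C@H]2O)nn1` keeps the core and changes one group on an aromatic nitrogen of a five-membered aromatic ring with 3 nitrogen: 3,4,5-trihydroxy-6-(hydroxymethyl)oxan-2-yl in place of 4-hydroxy-5-(hydroxymethyl)oxolan-2-yl (3,4,5-trihydroxy-6-(hydroxymethyl)oxan-2-yl in place of 4-hydroxy-5-(hydroxymethyl)oxolan-2-yl on an aromatic nitrogen).

Going by the values given here, no measured step swaps a five-membered ring here for a six-membered one, so the evidence is indirect. The two steps that replace a group on this same nitrogen to reach compound 3 are modest at most, and they suggest a modest step rather than a large one. Among the compounds with values here, the direction is a weak guess: no group tested on this nitrogen gives a number clearly lower than the one in compound 3. The expected change is a 2.1-fold higher number from compound 3 to compound 4 (0.33 log units; beyond the scatter), an estimated modest rise. For compound 4 the estimated value in this assay is 600 nM, with an expected range from 200 nM to 1800 nM.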

Compound 4, half-maximal inhibitory concentration: 420 nM
Compound 4: middle estimate off by 1.4-fold (0.15 log units), on the high side, and the stated range covers the measured number.
By their numbers in this assay, from the lowest: compounds 3, 4 and 2 (each within the scatter of the next); then compound 1.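

In this assay, going by these compounds alone, the earlier compounds held no six-membered ring on this aromatic nitrogen, and compound 4 now gives a direct reading: replacing 4-hydroxy-5-(hydroxymethyl)oxolan-2-yl with 3,4,5-trihydroxy-6-(hydroxymethyl)oxan-2-yl gives a 1.5-fold higher number from compound 3 to compound 4 (0.18 log units; within the scatter). So at this position, going from 8 to 11 heavy atoms and from 2 to 4 hydrogen-bond donors produces no difference that can be read. The other two comparisons place the new group clearly: a 1.1-fold lower number from compound 2 to compound 4 (0.05 log units; within the scatter) leaves these compounds indistinguishable, whereas a 2.5-fold lower number from compound 1 to compound 4 (0.41 log units; beyond the scatter) sets compound 4 apart from compound 1, whose 2,3-dihydroxypropyl group is the only one of the four without a ring, though nothing shown gives a measured reason for any of these numbers.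

The groups shown carry only oxygen as their hetero atom, so how an amine or a carboxylic acid in place of a hydroxyl on the oxane ring would read in this assay remains open. Also open, as far as these compounds go, is whether the arrangement of the stereocentres matters, since the 3,4,5-trihydroxy-6-(hydroxymethyl)oxan-2-yl group appears here in a single arrangement.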